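Trimming the side chain of compound 2

A few compounds are considered here, and "the series" means these few. Any claim that something is new, unique, unknown or untested is made for them only; others in the source may bear on it.

In a functional assay on U-937 cells (Homo sapiens) for cytotoxicity, read by MTT assay, with a stated time of 3 days (on this read-out higher numbers stand for weaker inhibition and lower numbers for stronger inhibition), compound 1 `N#Cc1c(Cl)nc(SCc2nc3ccccc3[nH]2)nc1-c1ccccc1` gives 4.46 nM and compound 2 `N#Cc1c(NNC(N)=S)nc(SCc2nc3ccccc3[nH]2)nc1-c1ccccc1` gives 3 nM, so these two numbers lie within the usual scatter of each other. Compound 3 `N#Cc1c(NC(N)=S)nc(SCc2nc3ccccc3[nH]2)nc1-c1ccccc1` is still unmeasured, and its structural change is a group of 3 heavy atoms (1 carbon, 1 nitrogen, 1 sulfur; no ring) in place of a group of 4 heavy atoms (1 carbon, 2 nitrogen, 1 sulfur; no ring), on a nitrogen on an aromatic ring. For the measured compounds named here, one measured step bears on this: a 1.5-fold lower number from compound 1 to compound 2 (0.17 log units; within the scatter), which swapped one chlorine atom on an aromatic carbon for a group of 5 heavy atoms. Going by the values given here, with only that step to go on, no change beyond the scatter is expected in this assay. The estimated step is a 1.2-fold higher number from compound 2 to compound 3 (0.07 log units; within the scatter). For compound 3, the expected value is 3.5 nM, with a range of 1.3 nM to 9 nM.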

Compound 3, half-maximal inhibitory concentration: 20 nM
For compound 3 the middle estimate is 5.7-fold (0.76 log units) below the measured one, and the stated range ends below it.
By their numbers in this assay, from the lowest: compounds 2 and 1 (each within the scatter of the next); then compound 3.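

In this assay, a small edit to this side chain matters: removing one nitrogen gives a 6.7-fold higher number from compound 2 to compound 3 (0.82 log units; beyond the scatter). The shorter group also separates from chlorine, with a 4.5-fold higher number from compound 1 to compound 3 (0.65 log units; beyond the scatter), although the longer group in compound 2 stays within the scatter of chlorine. So at this place on the shared core, the two similar side chains are not interchangeable. Nothing available here explains this shift. Going by these compounds, whether a simple amine or a longer chain at the same place would give a lower or higher number remains open.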